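Restoring a carboxy-bearing ring on the ether of compound 3

The source may hold more compounds than are shown below. What is called first, only, known or untested is meant among the compounds shown, and "the series" means these compounds.

Compound 1 `CC(=O)c1ccc(OCCCCOc2ccc(F)c(C(=O)O)c2)c(C)c1O` gives 75.5% in an assay on HEK293 cells for positive allosteric modulation of metabotropic glutamate receptor 2 (Rattus norvegicus), read by thallium flux, with a stated time of 2.5 min; on this read-out lower numbers stand for smaller maximal responses and higher numbers for larger maximal responses.
Compound 2 `Cc1c(OCCCCOc2ccc(C(=O)O)cc2Cl)ccc(C(=O)CC(C)C)c1O` gives 99.5% in this assay.
Compound 3 `COC(=O)c1ccc(OCCCCOc2ccc(C(=O)CC(C)C)c(O)c2C)cc1` gives 16.4% in this assay.

Among these three, compound 3 stands lowest. Its nearest neighbour is compound 1, which lies beyond the scatter above it, and its furthest is compound 2, also beyond the scatter. Compound 4 `Cc1c(OCCCCOc2ccc(F)c(C(=O)O)c2)ccc(C(=O)CC(C)C)c1O` differs from compound 3 in one place: 3-carboxy-4-fluorophenyl in place of 4-(methoxycarbonyl)phenyl on an oxygen on a saturated carbon.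

Going by the values given here, one measured step bears directly on this change: a number 83.1 percentage points lower from compound 2 to compound 3 (beyond the scatter). That step put the 4-(methoxycarbonyl)phenyl group in place of a ring carrying a carboxy group, and the maximal response collapsed. Compound 4 reverses that kind of exchange, bringing back a carboxy group on the ring, here as 3-carboxy-4-fluorophenyl. Among the compounds with values here, compound 1 carries this same 3-carboxy-4-fluorophenyl group and shows a large response, though it differs from compound 4 in its ketone, so no single step links them.

Compound 4 is therefore expected to give about 85% in this assay, within a range from 62% to 105%. The expected step is a number 68.6 percentage points higher from compound 3 to compound 4 (beyond the scatter), a large rise well beyond the scatter.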

Compound 4, largest response reached (reported as percent of maximum), in percent of the reference or control that the assay uses: 84.5%
For compound 4 the middle estimate is 0.5 percentage points above the measured one; low and high end bracket the measured number.
By their numbers in this assay, from the lowest: compound 3; then compounds 1 and 4 (each within the scatter of the next); then compound 2.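

In this assay the exchange on an oxygen on a saturated carbon gives a number 68.1 percentage points higher from compound 3 to compound 4 (beyond the scatter) as 3-carboxy-4-fluorophenyl enters, so the large gap to the 4-(methoxycarbonyl)phenyl compound now holds for a second carboxy-bearing group and not only for 4-carboxy-2-chlorophenyl. The two carboxy-bearing groups are nevertheless not interchangeable here, for the same place shows a number 15 percentage points lower from compound 2 to compound 4 (beyond the scatter) in a modest step. Elsewhere in the molecule, the exchange of isopropyl in place of hydrogen on a saturated chain carbon bound to a carbonyl carbon gives a number 9 percentage points higher from compound 1 to compound 4 (within the scatter) with 3-carboxy-4-fluorophenyl held fixed, so that exchange does not separate these two compounds on this read-out.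

Nothing given here accounts for the size of any of these steps. The compounds shown leave open whether a tetrazole or a primary amide on the same ring could stand in for the carboxylic acid, and how a longer chain on the ether oxygens would alter the maximal response.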